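Amide aryl variation on a shared thioacetamide core

This account rests on a few compounds, and the source may have more. Where it says the series, first, only, none or still open, it means among the compounds named here.

Measured compounds in a functional assay on PC-3 cells (Homo sapiens) for inhibition, read by MTT assay, with a stated time of 72 h; on this read-out higher numbers stand for weaker inhibition and lower numbers for stronger inhibition:
compound 1 `O=C(CSc1nc(Nc2ccccc2)c2ccccc2n1)Nc1ccccc1F` gives 12400 nM
compound 2 `O=C(CSc1nc(Nc2ccccc2)c2ccccc2n1)Nc1ccccc1Cl` gives 14600 nM
compound 3 `COc1cccc(NC(=O)CSc2nc(Nc3ccccc3)c3ccccc3n2)c1` gives 11600 nM

All three share one core and differ only in the aryl group on the amide-type nitrogen. Compound 3 sits level with the others: the step of a 1.1-fold lower number from compound 1 to compound 3 (0.03 log units; within the scatter) and the step of a 1.3-fold lower number from compound 2 to compound 3 (0.10 log units; within the scatter) both fall within the scatter, as does the step of a 1.2-fold higher number from compound 1 to compound 2 (0.07 log units; within the scatter). Nothing among these three compounds separates one aryl group from another.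

Compound 4 `O=C(CSc1nc(Nc2ccccc2)c2ccccc2n1)Nc1ccc(F)cc1` is not yet measured. It differs from compound 3 as follows: 4-fluorophenyl in place of 3-methoxyphenyl on an amide-type nitrogen. Every step measured so far at this position, whether a change of halogen or an exchange of the whole aryl group, has stayed within the scatter, so the same is expected here: the step of a 1.1-fold higher number from compound 3 to compound 4 (0.05 log units; within the scatter) is expected to be no larger than the scatter, with no direction favoured. Compound 4 is therefore estimated at 13000 nM in this assay, with a range from 6000 nM to 28000 nM.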

Compound 4, half-maximal inhibitory concentration: 9560 nM
Compound 4: middle estimate off by 1.4-fold (0.13 log units), on the high side, and the stated range covers the measured number.
By their numbers in this assay, from the lowest: compounds 4, 3, 1 and 2 (each within the scatter of the next).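

In this assay a fluoro group at the 4 position of the phenyl ring is now covered, and the steps of a 1.2-fold lower number from compound 3 to compound 4 (0.08 log units; within the scatter) and a 1.3-fold lower number from compound 1 to compound 4 (0.11 log units; within the scatter) and a 1.5-fold lower number from compound 2 to compound 4 (0.18 log units; within the scatter) all stay within the scatter, the last being the largest step seen so far at this position. Moving from 2-fluorophenyl to 4-fluorophenyl on the amide-type nitrogen therefore separates nothing, and the exchange of 3-methoxyphenyl for 4-fluorophenyl, which removes a hydrogen-bond acceptor from this group, separates nothing either. No available evidence bears on this result.

From the compounds shown here alone, all four groups at this position are substituted phenyl rings, so it remains open whether a carboxylic acid or an amine on the ring, or a longer alkyl chain in place of the ring, would give a step beyond the scatter. Going by these compounds, the shared core is constant throughout, so the effect of any change there also remains open.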